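The source may report more compounds than this note shows. Statements on the series, on what has been measured and on what is new or still open speak of the compounds shown alone.

Measured compounds:
- compound 1 `COc1ccc(-c2nn(-c3ccccc3)cc2C(=O)NOCc2ccccc2F)cc1`: in a functional assay on MCF7 cells (Homo sapiens) for antiproliferative activity, read by MTT assay, with a stated time of 48 h, in the presence of a further agent that is not named here (on this read-out lower numbers stand for stronger inhibition of growth and higher numbers for weaker inhibition of growth), compound 1 gives 6000 nM
- compound 2 `COc1ccc(-c2nn(-c3ccccc3)cc2C(=O)NOCc2ccccc2Cl)cc1`: compound 2 gives 3730 nM
- compound 3 `COc1ccc(-c2nn(-c3ccccc3)cc2C(=O)NOCc2ccc(Cl)cc2Cl)cc1`: compound 3 gives 2570 nM

Compound 1 stands at the highest number of the three. The gap to compound 2, a 1.6-fold lower number from compound 1 to compound 2 (0.21 log units; within the scatter), lies within the scatter; the gap to compound 3, a 2.3-fold lower number from compound 1 to compound 3 (0.37 log units; beyond the scatter), is modest but beyond it. From compound 2 to compound 3 the step is a 1.5-fold lower number from compound 2 to compound 3 (0.16 log units; within the scatter), again within the scatter.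

Compound 4 `O=C(NOCc1ccccc1F)c1cn(-c2ccccc2)nc1-c1ccc(F)cc1` differs from compound 1 at a different part of the molecule: fluoro in place of methoxy on an aromatic carbon, on an aromatic carbon para to a large group. Going by the values given here, all three measured steps concern the benzyloxy side and none touches this ring, so no measured step bears directly on the change, and the series gives no guide to its direction. The expectation therefore is no step beyond the scatter, with a wide range: for compound 4 the estimate is 6000 nM, between 2000 nM and 18000 nM, meaning an expected step of no change at the digits printed from compound 1 to compound 4 (within the scatter).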

Compound 4, concentration for 50% growth inhibition: 12000 nM
Compound 4: middle estimate off by 2.0-fold (0.30 log units), on the low side, and the stated range covers the measured number.
By their numbers in this assay, from the lowest: compounds 3, 2, 1 and 4 (each within the scatter of the next, the first and the last beyond it).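

In this assay, going by these compounds alone, the change from 4-methoxyphenyl to 4-fluorophenyl gives a 2.0-fold higher number from compound 1 to compound 4 (0.30 log units; within the scatter) and is the only reading so far on this side of the molecule, as the earlier steps all concern the benzyloxy side. This step stays within the scatter, so replacing methoxy with fluoro on this aromatic carbon cannot be told apart from no change in growth inhibition, even though the group is swapped for one with fewer heavy atoms and no hydrogen-bond acceptor. Nothing measured here bears on the reason for the size of this step.

Still open, from the compounds shown here alone, is how an amine, a carboxylic acid or a longer ethoxy chain would read at this position. Also open, going by these compounds, is whether fluoro here would give a similar step with 2-chlorophenyl or 2,4-dichlorophenyl on the benzyloxy side.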